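The compounds below may be only part of what the source reports. "The series", "measured", "known", "first", "only" and "open" are said of these compounds alone.

Measured compounds:
compound 1 `CCOc1ccc(Br)cc1C(C)NC(=O)N(C)S(=O)(=O)c1ccc(C)cc1` gives 28600 nM
compound 2 `Cc1ccc(S(=O)(=O)N(C)C(=O)NC(C)c2cc(Br)ccc2OC(C)C)cc1` gives 34700 nM
compound 3 `CCOc1ccc(Br)cc1C(C)NC(=O)NS(=O)(=O)c1ccc(Cl)cc1` gives 171000 nM

All three were tested in a functional assay on thoracic aorta (Rattus norvegicus, strain Wistar), with a stated time of 15 min; on this read-out lower numbers stand for an effect already at smaller amounts and higher numbers for an effect only at larger amounts of compound. Compound 3 stands apart from the others: it needs a higher concentration than compound 2 and a higher one than compound 1, and both gaps lie beyond the scatter. The difference between the core of compound 3 and that of compound 2 is not broken down here.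

The change from compound 2 to compound 1 is hydrogen in place of methyl on a saturated chain carbon bound to an oxygen on an aromatic ring and a saturated chain carbon. Its step in this assay was a 1.2-fold lower number from compound 2 to compound 1 (0.08 log units; within the scatter).

Compound 4 `COc1ccc(Br)cc1C(C)NC(=O)NS(=O)(=O)c1ccc(Cl)cc1` is not yet measured. It differs from compound 3 by hydrogen in place of methyl on a saturated chain carbon bound to an oxygen on an aromatic ring. Going by the values given here, this is the same kind of change as the one from compound 2 to compound 1, though the place differs: there the carbon is bound to an oxygen on an aromatic ring and a saturated chain carbon, here only to an oxygen on an aromatic ring. Because a 1.2-fold lower number from compound 2 to compound 1 (0.08 log units; within the scatter) stayed within the scatter, the step of a 1.1-fold lower number from compound 3 to compound 4 (0.06 log units; within the scatter) is expected to be small as well. Compound 4 is therefore estimated at 150000 nM, with a likely range from 60000 nM to 400000 nM.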

Compound 4, half-maximal effective concentration: 80900 nM
For compound 4 the middle estimate is 1.9-fold (0.27 log units) above the measured one; the measured number falls inside the stated range.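

Replacing ethoxy with methoxy gives a 2.1-fold lower number from compound 3 to compound 4 (0.33 log units; beyond the scatter) in this assay. Set beside the earlier case on a different core, the two steps cannot be told apart, so in this small set the change carries from one core to the other without a detectable difference: the same change on two cores in this assay, a 1.2-fold lower number (0.08 log units; within the scatter) from compound 2 to compound 1 and a 2.1-fold lower number (0.33 log units; beyond the scatter) from compound 3 to compound 4, 1.7-fold (0.24 log units) apart, within the scatter of two such steps. Going by these compounds alone, this does not show that the step has a fixed size on every core: only two cores are compared, one step lies within the scatter and the other beyond it, and the numbers give no reason for the step.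

The compounds shown leave open what a longer chain, such as butoxy, would do. They also leave open what an amine in place of the ethoxy group would do.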